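A Chloromethyl Swap on the Weakest Amide So Far

The compounds below may be only part of what the source reports. "The series", "measured", "known", "first", "only" and "open" are said of these compounds alone.

Three amides have been measured in a functional assay on HCT-116 cells (Homo sapiens) for inhibition, read by MTT assay, with a stated time of 48 h; a higher number here means a weaker inhibitor, a lower number a stronger inhibitor. Compound 1 (`CCCCC(=O)N(Cc1ccc(OC)c(O)c1)c1cc(OC)c(OC)c(OC)c1`) gives 170 nM, and compound 2 (`COc1ccc(CN(C(C)=O)c2cc(OC)c(OC)c(OC)c2)cc1O`) gives 270 nM. Compound 3 (`C/C=C/C(=O)N(Cc1cc(OC)c(OC)c(OC)c1)c1ccc(OC)c(O)c1`) gives 8450 nM, the highest of the three numbers and beyond the scatter from both of the others.

Compound 4 (`COc1ccc(N(Cc2cc(OC)c(OC)c(OC)c2)C(=O)CCl)cc1O`) keeps the rest of compound 3 and alters one group: chloromethyl in place of prop-1-en-1-yl on a carbonyl carbon. Put simply, chloromethyl stands in place of prop-1-en-1-yl on a carbonyl carbon.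

Going by the values given here, only one measured step bears on this change, since it also alters what the carbonyl carbon carries: a 1.6-fold higher number from compound 1 to compound 2 (0.20 log units; within the scatter). That step stays within the scatter, but it is only indirect evidence. Among the compounds with values here, compound 1 and compound 2 differ from compound 3 in more than this group, and no measured compound carries chloromethyl. The expectation in this assay is therefore no step beyond the scatter, with compound 4 remaining in the range of compound 3 rather than joining the two lower numbers. The expected change is a 1.7-fold lower number from compound 3 to compound 4 (0.23 log units; within the scatter). The estimate for compound 4 is 5000 nM, with an expected range from 1000 nM to 20000 nM.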

Compound 4, half-maximal inhibitory concentration: 22500 nM
For compound 4 the middle estimate is 4.5-fold (0.65 log units) below the measured one; measured number above the stated range.
By their numbers in this assay, from the lowest: compounds 1 and 2 (each within the scatter of the next); then compound 3; then compound 4.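

In this assay, the group on the carbonyl carbon of this amide proves able to shift the number beyond the scatter: chloromethyl in place of prop-1-en-1-yl gives a 2.7-fold higher number from compound 3 to compound 4 (0.43 log units; beyond the scatter), a modest step upward, so compound 4 is a weaker inhibitor than compound 3. Going by these compounds alone, the earlier step near a carbonyl carbon, a 1.6-fold higher number from compound 1 to compound 2 (0.20 log units; within the scatter), lay within the scatter and belonged to a pair with a different core, so this is the first measured sign that a swap at this place in the core of compound 3 matters. The change removes the double bond outside aromatic rings and brings in a chlorine, and this one step cannot separate those two differences; no measurement here accounts for the shift in either direction.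

From the compounds shown here alone, it remains open whether another group on this carbonyl carbon, such as bromomethyl, aminomethyl or phenyl, would give a number nearer that of compound 3 or that of compound 4. Going by these compounds, it is also open whether the same swap would produce a step of similar size on the core of compound 1, where the number is far lower.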